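The compounds below may be only part of what the source reports. "The series", "measured", "known", "first", "only" and "open" are said of these compounds alone.

Compound 1 `COCc1cc(CCCOc2c(C)cc(-c3noc(C(F)(F)F)n3)cc2C)on1` — 1.58 h
Compound 2 `COCc1cc(CCCOc2c(C)cc(-c3noc(C4CC4)n3)cc2C)on1` — reported only as a limit, > 2.5 h
Compound 3 `Cc1cc(-c2noc(C(F)(F)F)n2)cc(C)c1OCCCc1cc(CO)no1` — reported only as a limit, > 2.5 h

All three were measured in an in vitro ADME assay on microsomes from liver (Simiiformes); on this read-out higher numbers stand for a longer-lived compound and lower numbers for a shorter-lived compound. In this assay compound 1 gives 1.58 h. For compound 2 the read-out is a limit of the assay, > 2.5 h. For compound 3 the read-out is likewise a limit, > 2.5 h. Two changes lead away from compound 1. The first, (cyclopropyl in place of trifluoromethyl on an aromatic carbon), brings an at least 1.5-fold higher number from compound 1 to compound 2 (0.19 log units; that floor lies within the scatter). The second, (hydrogen in place of methyl on an oxygen on a saturated carbon), brings an at least 1.5-fold higher number from compound 1 to compound 3 (0.19 log units; that floor lies within the scatter); this is also how the core of compound 3 differs from the core of compound 1.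

Compound 4 `Cc1cc(-c2noc(C3CC3)n2)cc(C)c1OCCCc1cc(CO)no1` has not yet been measured. Among the compounds with values here, it differs from compound 3 by cyclopropyl in place of trifluoromethyl on an aromatic carbon, the same change as the one from compound 1 to compound 2. Because two of the three values already sit at the limit of > 2.5 h in this assay, at which 2 of the 3 values shown sit, the size of the new step is expected to be hard to read. Compound 4 is expected to show a step that the limit leaves unreadable from compound 3 to compound 4 in this assay, resting on an at least 1.5-fold higher number from compound 1 to compound 2 (0.19 log units; that floor lies within the scatter). Compound 4 is therefore estimated at 4 h, within 2.5 h to 8 h, and most likely reported again only as a limit.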

Compound 4, half-life: > 2.5 h
Compound 4 ended at the assay's limit; the forecaster's own chance of this, stated with the estimate: 85%; the middle value does not contradict the limit.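

In this assay compound 4 is reported only as a limit, > 2.5 h. No size can be read for the steps from compound 3 or compound 2 to compound 4, because both ends of each step are limits: the limit of > 2.5 h in this assay, at which 3 of the 4 values shown sit. The compounds shown leave open how far compound 2, compound 3 and compound 4 lie beyond that limit, and so how they rank against one another.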